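Cyclopentyl to 4-Bromophenyl on the Amine Nitrogen

The source may hold more compounds than are shown below. What is called first, only, known or untested is meant among the compounds shown, and "the series" means these compounds.

compound 1 `O=C1C=C(Nc2ccc(I)cc2)C(=O)c2c1nc1n2[C@H]2OC[C@@H](O)[C@H]2OC1`: 1400 nM
compound 2 `O=C1C=C(Nc2ccccc2)C(=O)c2c1nc1n2[C@H]2OC[C@@H](O)[C@H]2OC1`: 1730 nM
compound 3 `O=C1C=C(NC2CCCC2)C(=O)c2c1nc1n2[C@H]2OC[C@@H](O)[C@H]2OC1`: > 8000 nM

In a functional assay on MGC-803 cells (Homo sapiens) for inhibition, read by sulforhodamine B assay (on this read-out lower numbers stand for stronger inhibition and higher numbers for weaker inhibition), compound 1 gives 1400 nM and compound 2 gives 1730 nM; the gap between them, a 1.2-fold higher number from compound 1 to compound 2 (0.09 log units; within the scatter), is small. Going by these compounds, compound 3 gives only a limit of this assay, > 8000 nM, so its true number is unknown. It sits at the limit of > 8000 nM in this assay, at which 1 of the 3 values shown sits. Compound 4 `O=C1C=C(Nc2ccc(Br)cc2)C(=O)c2c1nc1n2[C@H]2OC[C@@H](O)[C@H]2OC1` carries the change (4-bromophenyl in place of cyclopentyl on an amine nitrogen). Two measured steps run the opposite way: an at least 5.7-fold higher number from compound 1 to compound 3 (0.75 log units; beyond the scatter) and an at least 4.6-fold higher number from compound 2 to compound 3 (0.66 log units; beyond the scatter). Read backwards, both point to a clearly lower number for compound 4 in this assay, and the 4-iodophenyl and phenyl results of compound 1 and compound 2 suggest where it should land. Compound 4 is therefore expected at 1500 nM, between 700 nM and 3500 nM. The expected step is an at least 5.3-fold lower number from compound 3 to compound 4 (0.72 log units; beyond the scatter).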

Compound 4, half-maximal inhibitory concentration: 1010 nM
Beside the measured number, compound 4's estimate is 1.5-fold (0.17 log units) above it; measured number inside the range.
By their numbers in this assay, from the lowest: compounds 4, 1 and 2 (each within the scatter of the next). At a limit, above all of these: compound 3.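

Compound 3 gives > 8000 nM, which is a limit of the assay. A third aromatic group on the amine nitrogen, 4-bromophenyl, again separates clearly from cyclopentyl, with an at least 7.9-fold lower number from compound 3 to compound 4 (0.89 log units; beyond the scatter), so the difference no longer rests on phenyl and 4-iodophenyl alone. Bromo adds no readable change on that ring, with a 1.7-fold lower number from compound 2 to compound 4 (0.23 log units; within the scatter) and a 1.4-fold lower number from compound 1 to compound 4 (0.14 log units; within the scatter).

Going by these compounds, how a 4-methoxyphenyl or 4-carboxyphenyl group would read on this nitrogen stays open. So does the effect of a benzyl group, which would place a carbon link before the aromatic ring.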